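The source may hold more compounds than are shown below. What is called first, only, known or untested is meant among the compounds shown, and "the series" means these compounds.

Measured in a functional assay on MV4-11 cells (Homo sapiens) for antiproliferative activity, read by luminescence and CellTiter-Glo, with a stated time of 72 h; on this read-out higher numbers stand for weaker inhibition and lower numbers for stronger inhibition:
- compound 1 `COc1ccc(Cn2nc(Nc3cccc(C(C)C)c3)c3ccc(-c4c(C)noc4C)cc32)cc1`: 8100 nM
- compound 2 `CNc1cc(-c2ccc3cnn(Cc4cc(OC)cc(OC)c4)c3c2)cn(C)c1=O`: 190 nM
- compound 3 `CNc1cc(-c2ccc3cnn(Cc4ccc(F)c(F)c4)c3c2)cn(C)c1=O`: 320 nM

Compound 3, at 320 nM, sits within the usual scatter of compound 2, at 190 nM, so these two cannot be ranked. Compound 1, at 8100 nM, shows a much higher number, meaning much weaker inhibition. However, compound 1 differs from the other two in more than one place, so it gives no clean comparison.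

The next structure is compound 4 `CNc1cc(-c2ccc3cnn(Cc4ccc(OC)c(F)c4)c3c2)cn(C)c1=O`. Its 3-fluoro-4-methoxyphenyl replaces the 3,4-difluorophenyl of compound 3, which amounts to methoxy in place of fluoro on an aromatic carbon.

Among the compounds with values here, only one measured step touches this phenyl group: a 1.7-fold higher number from compound 2 to compound 3 (0.23 log units; within the scatter). Swapping two methoxy groups for two fluoro groups, at partly different places, therefore moved the number by no more than the scatter. Compound 4 carries one group of each kind, which suggests a small change, although no single swap of this kind has been measured here. No clear direction can be drawn from this, so no step beyond the scatter is expected in this assay. The estimate amounts to a 1.3-fold lower number from compound 3 to compound 4 (0.11 log units; within the scatter), which is expected to stay within the scatter.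

For compound 4 the estimated value is 250 nM, with an expected range from 110 nM to 560 nM.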

Compound 4, half-maximal inhibitory concentration: 4980 nM
The estimate for compound 4 lay 20-fold (1.30 log units) below the measured number; measured number above the stated range.
By their numbers in this assay, from the lowest: compounds 2 and 3 (each within the scatter of the next); then compounds 4 and 1 (each within the scatter of the next).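

In this assay, methoxy in place of fluoro on an aromatic carbon, ortho to a fluoro group and para to a large group, gives a 16-fold higher number from compound 3 to compound 4 (1.19 log units; beyond the scatter). So this place on the ring responds strongly to a small swap, something the near-equal numbers of the two earlier compounds with this same core gave no hint of. Methoxy as such does not go with a high number here: the step from 3,5-dimethoxyphenyl to 3-fluoro-4-methoxyphenyl is a 26-fold higher number from compound 2 to compound 4 (1.42 log units; beyond the scatter), so among these compounds the loss follows the one with methoxy at the place named, not the count of methoxy groups, and compound 2 with two of them goes against any simple rule about methoxy. Nothing given here accounts for the size of this jump.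

Still open, from the compounds shown here alone, is whether another group at the same place, such as a hydroxyl, a methyl, a chlorine or an amine, would keep the number near that of compound 3 or raise it as methoxy does. Also open, going by these compounds, is whether methoxy at this place gives the same result without the neighbouring fluoro group, as in a plain 4-methoxyphenyl.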